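The source may hold more compounds than are shown below. What is called first, only, known or untested is meant among the compounds shown, and "the series" means these compounds.

Compounds measured in a physicochemical assay for solubility; a lower number here means a less soluble compound, a higher number a more soluble compound:
- Compound 1 `O=C(O)c1ccc(C(=O)/C(=C\c2ccc(Br)c([N+](=O)[O-])c2)SCc2ccc(Cl)cc2)cc1`: < 1000 ug/mL (a limit)
- Compound 2 `O=C(O)c1ccc(C(=O)/C(=C\c2ccc(Cl)c([N+](=O)[O-])c2)SCc2ccc(F)cc2)cc1`: < 1000 ug/mL (a limit)
- Compound 3 `O=C(O)c1ccc(C(=O)/C(=C\c2ccc(Br)c([N+](=O)[O-])c2)SCc2ccc(Cl)cc2Cl)cc1`: < 1000 ug/mL (a limit)

Every known result here is the same boundary of the assay: the limit of < 1000 ug/mL in this assay, at which 3 of the 3 values shown sit. Compound 3 therefore has only its limit of < 1000 ug/mL, not a true number.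

Compound 4 `O=C(O)c1ccc(C(=O)/C(=C\c2ccc(Br)c([N+](=O)[O-])c2)SCc2ccc(F)cc2)cc1` carries 4-fluorophenyl in place of 2,4-dichlorophenyl on a saturated chain carbon bound to a sulfur.

Among the measured compounds shown here, one measured step bears on this change: a step that the two limits leave unreadable from compound 1 to compound 3. Its size cannot be read, so it supports no expected direction, and no change beyond the usual scatter is expected in this assay. The expected step runs a step that the limit leaves unreadable from compound 3 to compound 4. For compound 4 the estimated solubility is 400 ug/mL, with an expected range of 50 ug/mL to 1000 ug/mL.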

Compound 4, solubility: < 1000 ug/mL
Compound 4: a limit, no number; the forecaster's own chance of this, stated with the estimate: 90%; the middle value is on the limit's open side.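

In this assay no new step can be read from compound 1, compound 2 or compound 3 to compound 4, because each result is only a limit: the limit of < 1000 ug/mL in this assay, at which 4 of the 4 values shown sit. Going by these compounds, the true solubility of all four compounds stays open, and so does any effect of their differing groups on it.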